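Replacing 4-nitrophenyl with 2,3-dichlorophenyl on the shared core

The source may report more compounds than this note shows. Statements on the series, on what has been measured and on what is new or still open speak of the compounds shown alone.

In a functional assay on MCF7 cells (Homo sapiens) for antiproliferative activity, read by MTT assay, with a stated time of 72 h (on this read-out higher numbers stand for weaker inhibition and lower numbers for stronger inhibition), compound 1 (`O=C(N/N=C/c1ccc(Br)cc1)Nc1ccc(Oc2ccnc3[nH]ccc23)c(F)c1`) gives 930 nM, while compound 2 (`O=C(N/N=C/c1ccc([N+](=O)[O-])cc1)Nc1ccc(Oc2ccnc3[nH]ccc23)c(F)c1`) gives 4000 nM, the higher of the two numbers. Compound 3 (`O=C(N/N=C/c1cccc(Cl)c1Cl)Nc1ccc(Oc2ccnc3[nH]ccc23)c(F)c1`) carries 2,3-dichlorophenyl in place of 4-nitrophenyl on a carbon with a double bond to nitrogen. Within the data shown here, only one measured step bears on this change: nitro in place of bromo on an aromatic carbon gave a 4.3-fold higher number from compound 1 to compound 2 (0.63 log units; beyond the scatter), modest but beyond the scatter. Compound 3 also lacks the nitro, so a modest step toward a lower number is expected in this assay. The estimated step is a 3.1-fold lower number from compound 2 to compound 3 (0.49 log units; beyond the scatter). Compound 3 is expected at 1300 nM, with an estimated range of 400 nM to 4000 nM.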

Compound 3, half-maximal inhibitory concentration: "not active" (no number reported)
Compound 3: no number reported, and the estimate cannot be compared.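

In this assay, among these compounds, compound 3 was reported as not active, without a number, so no step from compound 2 to compound 3 can be read. Nothing shown here accounts for this result. The compounds shown leave open how far 2,3-dichlorophenyl and 4-nitrophenyl differ on the shared core in this assay.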